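A few compounds are considered here, and "the series" means these few. Any claim that something is new, unique, unknown or untested is made for them only; others in the source may bear on it.

Compound 1 `O=Cc1ccc(-c2cn3ccnc3c(-c3ccc4ncn(C5CCCCC5)c4c3)n2)cc1` carries a 4-formylphenyl group on the shared core, and in a functional assay on SK-MEL-5 cells (Homo sapiens) for inhibition, read by sulforhodamine B assay, with a stated time of 48 h, tested at 10 uM (a higher number here means more inhibition at the concentration tested (going by the name of the read-out), a lower number less inhibition), compound 1 gives 56.5%. Compound 2 `c1ccc2c(-c3cn4ccnc4c(-c4ccc5ncn(C6CCCCC6)c5c4)n3)cccc2c1` differs from it only by naphthalen-1-yl in place of 4-formylphenyl on an aromatic carbon; in this assay compound 2 gives 4.06%, a step of a number 52.4 percentage points lower from compound 1 to compound 2 (beyond the scatter). Compound 3 `O=Cc1ccc(-c2cn3ccnc3c(-c3ccc4ncn(Cc5ccccc5)c4c3)n2)cc1` differs from compound 1 by benzyl in place of cyclohexyl on an aromatic nitrogen, and in this assay compound 3 gives 56.5%, a step of no change at the digits printed from compound 1 to compound 3 (within the scatter). Compound 4 `c1ccc(Cn2cnc3ccc(-c4nc(-c5cccc6ccccc56)cn5ccnc45)cc32)cc1` has not yet been measured; it differs from compound 3 by naphthalen-1-yl in place of 4-formylphenyl on an aromatic carbon, the same change, at the same place, that turned compound 1 into compound 2. Because that earlier step was a number 52.4 percentage points lower from compound 1 to compound 2 (beyond the scatter), and because compound 3 starts at 56.5%, compound 4 is expected to show a step of a number 50.5 percentage points lower from compound 3 to compound 4 (beyond the scatter). Compound 4 is therefore estimated at 6%.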

Compound 4, a percentage reported as inhibition, at one concentration (the size of the read-out at that concentration, not a potency): 9.69%
The estimate for compound 4 lay 3.7 percentage points below the measured number; the range from low to high includes it.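

In this assay, the step of a number 46.8 percentage points lower from compound 3 to compound 4 (beyond the scatter) matches the one seen with cyclohexyl on the ring nitrogen, so naphthalen-1-yl in place of 4-formylphenyl carries over between these two cores: the same change on two cores in this assay, a number 52.4 percentage points lower (beyond the scatter) from compound 1 to compound 2 and a number 46.8 percentage points lower (beyond the scatter) from compound 3 to compound 4, 5.6 percentage points apart, within the scatter of two such steps

Benzyl in place of cyclohexyl also carries over, with a number 5.6 percentage points higher from compound 2 to compound 4 (within the scatter): the same change on two cores in this assay, no change at the digits printed (within the scatter) from compound 1 to compound 3 and a number 5.6 percentage points higher (within the scatter) from compound 2 to compound 4, 5.6 percentage points apart, within the scatter of two such steps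

This agreement rests on just two pairs of compounds, so it does not show that either change would behave the same way on other cores, nor which part of either group sets the result.

The compounds shown leave open whether losing the formyl group or gaining the second aromatic ring matters more. An unsubstituted phenyl, a 4-carboxyphenyl or a 4-aminophenyl group at the same place could help separate the two.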